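Butyl to cyclopentyl: expected partition coefficient of compound 4

The compounds below may be only part of what the source reports. "The series", "measured", "known", "first", "only" and "open" are said of these compounds alone.

Measured so far in a physicochemical assay for lipophilicity, using the shake flask method; a lower number here means a more polar compound, a higher number a more lipophilic compound:
compound 1 `N/N=C/c1c(N)ncnc1Oc1ccc(NC(=O)C2(C(=O)Nc3ccc(F)cc3)CC2)cc1F` gives 2.25
compound 2 `CC(C)(C)OC(=O)N/N=C/c1c(N)ncnc1Oc1ccc(NC(=O)C2(C(=O)Nc3ccc(F)cc3)CC2)cc1F` gives 3.7
compound 3 `CCCCO/N=C/c1c(N)ncnc1Oc1ccc(NC(=O)C2(C(=O)Nc3ccc(F)cc3)CC2)cc1F` gives 4.2

Compound 3 stands highest of the three in this assay, with compound 2 nearest and compound 1 furthest. Compound 4 `Nc1ncnc(Oc2ccc(NC(=O)C3(C(=O)Nc4ccc(F)cc4)CC3)cc2F)c1/C=N/OC1CCCC1` differs from compound 3 in one place: cyclopentyl in place of butyl on an oxygen. Among the measured compounds shown here, none of the measured steps makes this exchange: a number 1.45 log units higher from compound 1 to compound 2 (beyond the scatter), a number 1.95 log units higher from compound 1 to compound 3 (beyond the scatter) and a number 0.50 log units higher from compound 2 to compound 3 (beyond the scatter) all alter the group on the double-bonded nitrogen, not the butyl. The present change is smaller in kind than any of those, so only a small rise in this assay, around the scatter, is expected, and the step from compound 3 to compound 4 is estimated at a number 0.20 log units higher from compound 3 to compound 4 (within the scatter). Compound 4 is therefore expected to give 4.4, between 4 and 4.8.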

Compound 4, partition coefficient: 4.27
The estimate for compound 4 lay 0.13 log units above the measured number, within the range that was stated.
By their numbers in this assay, from the lowest: compound 1; then compound 2; then compounds 3 and 4 (each within the scatter of the next).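

In this assay, the exchange on the oxygen gives a number 0.07 log units higher from compound 3 to compound 4 (within the scatter), so a five-membered ring of carbon in place of the open butyl chain does not separate these two compounds. Among the compounds shown here, with cyclopentyloxy on the double-bonded nitrogen, the earlier compounds remain clearly apart: a number 0.57 log units higher from compound 2 to compound 4 (beyond the scatter) and a number 2.02 log units higher from compound 1 to compound 4 (beyond the scatter). No evidence is available to account for any of these steps.

The compounds shown leave open whether a methyl group, a chain longer than butyl, or an amine or carboxylic acid carried on this oxygen would move the number beyond the scatter.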